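This account rests on a few compounds, and the source may have more. Where it says the series, first, only, none or still open, it means among the compounds named here.

Three compounds from one series share a core bearing a dimethylamino group, two methyl groups, a hydroxy group and a long saturated chain. Compound 1 `Cc1c(N(C)C)nc(CCCCCCCCCCO)c(O)c1C` carries a hydroxy on that chain and gives 20% in a functional assay on cells (Lymphocyte, Homo sapiens), read by trypan blue exclusion, with a stated time of 16 h, tested at 0.1 uM; on this read-out higher numbers stand for a stronger effect at the one concentration tested and lower numbers for a weaker effect. Compound 2 `CCCCCCCCCCc1nc(N(C)C)c(C)c(C)c1O` gives 6%, and compound 3 `CCCCCCCCCCCCCCCCCCCc1nc(N(C)C)c(C)c(C)c1O` gives 4%. On these numbers compound 3 holds the lowest value of the three, yet the step of a number 2 percentage points lower from compound 2 to compound 3 (within the scatter) is within the scatter, so compound 2 and compound 3 are not separated, whereas the step of a number 16 percentage points lower from compound 1 to compound 3 (beyond the scatter) is beyond it.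

Compound 4 `CCCCCCCCCCCCCCCCc1nc(N(C)C)c(C)c(C)c1O` differs from compound 3 by hydrogen in place of propyl on a saturated chain carbon, ten or more bonds along the chain from an aromatic carbon. Among the compounds with values here, the one measured step at the same place, a number 2 percentage points lower from compound 2 to compound 3 (within the scatter), shows that a large change in chain length there left the read-out within the scatter, and the shorter cut from compound 3 to compound 4 is expected to do the same, giving an expected step of a number 1 percentage points higher from compound 3 to compound 4 (within the scatter). Compound 4 is therefore estimated at 5%, with a range from 0% to 13%.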

Compound 4, a percentage reported as activity, at one concentration (the size of the read-out at that concentration, not a potency): 29%
For compound 4 the middle estimate is 24 percentage points below the measured one, outside the stated range (above it).
By their numbers in this assay, from the lowest: compounds 3 and 2 (each within the scatter of the next); then compounds 1 and 4 (each within the scatter of the next).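

Chain length at this place does change the read-out in this assay: hydrogen in place of propyl gives a number 25 percentage points higher from compound 3 to compound 4 (beyond the scatter) and hexyl in place of hydrogen gives a number 23 percentage points higher from compound 2 to compound 4 (beyond the scatter) on the same chain, so the flat result from compound 2 and compound 3 does not hold for every chain length. Among these three compounds, the chain of intermediate length gives the highest value, and a plain alkyl chain is not always tied to a low number, since hexyl in place of hydroxy gives a number 9 percentage points higher from compound 1 to compound 4 (within the scatter) and so does not separate the two. Nothing measured here accounts for this rise.

From the compounds shown here alone, how the read-out behaves at other chain lengths between those of compound 2 and compound 3 remains open. Also open is whether a terminal amine or carboxylic acid on the chain of compound 4 would keep this effect, or how any of these compounds behaves at other concentrations.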